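Working notes on three measured amides and one pending

This account rests on a few compounds, and the source may have more. Where it says the series, first, only, none or still open, it means among the compounds named here.

Measured so far:
compound 1, `CC(C)(N)CC(=O)N[C@@H]1CCc2ccccc2N(Cc2ccc(-c3ccccc3C(N)=O)cc2)C1=O`, 0.08 uM in a functional assay (Pituitary gland cell) with Rattus norvegicus as the target; a lower number here means that less compound is needed, a higher number that more compound is needed for the effect
compound 2, `CC(O)Cn1nnc(-c2ccccc2-c2ccc(CN3C(=O)[C@H](NC(=O)CC(C)(C)N)CCc4ccccc43)cc2)n1`, 0.05 uM
compound 3, `CC(O)Cn1nnnc1-c1ccccc1-c1ccc(CN2C(=O)[C@H](NC(=O)CC(C)(C)N)CCc3ccccc32)cc1`, 0.05 uM

Compound 3 sits level with compound 2 at the digits given, the two together being the lowest numbers of the three; the wider gap is a 1.6-fold lower number from compound 1 to compound 3 (0.20 log units; within the scatter), and between the two tetrazole isomers no change at the digits printed from compound 2 to compound 3 (within the scatter). All three, then, lie within the usual scatter of one another, so no order among them can be stated.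

Compound 4, `CC(C)(N)CC(=O)N[C@@H]1CCc2ccccc2N(Cc2ccc(-c3ccccc3S(=O)(=O)NC(C)(C)C)cc2)C1=O`, has not yet been measured. Its change from compound 3 is (tert-butyl)sulfamoyl in place of 1-(2-hydroxypropyl)-1H-tetrazol-5-yl on an aromatic carbon.

Only indirect steps bear on it. The shift from carbamoyl to a tetrazolyl gave a 1.6-fold lower number from compound 1 to compound 2 (0.20 log units; within the scatter) and a 1.6-fold lower number from compound 1 to compound 3 (0.20 log units; within the scatter), and the swap of the two tetrazolyl isomers gave no change at the digits printed from compound 2 to compound 3 (within the scatter); none of these crossed the scatter. Within the data shown here, nothing measured contains a sulfamoyl group, so the new group has no direct precedent here. Across three different groups on this aromatic carbon the numbers hardly moved, so for compound 4 the expected step is a 1.4-fold higher number from compound 3 to compound 4 (0.15 log units; within the scatter), not beyond the scatter. The estimate for compound 4 in this assay is 0.07 uM, within 0.02 uM to 0.25 uM.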

Compound 4, concentration for half-maximal effect: 4 uM
Compound 4: middle estimate off by 57-fold (1.76 log units), on the low side; the measured number lies above the stated range.
By their numbers in this assay, from the lowest: compounds 2, 3 and 1 (each within the scatter of the next); then compound 4.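

Among these compounds, this aromatic carbon, ortho to a large group, accepts less variety than the earlier compounds suggested. In this assay the change to (tert-butyl)sulfamoyl gives an 80-fold higher number from compound 3 to compound 4 (1.90 log units; beyond the scatter) and an 80-fold higher number from compound 2 to compound 4 (1.90 log units; beyond the scatter) and a 50-fold higher number from compound 1 to compound 4 (1.70 log units; beyond the scatter), all large and beyond the scatter, whereas carbamoyl and the two hydroxypropyl tetrazolyl groups stayed within the scatter of one another. Against the 1-(2-hydroxypropyl)-1H-tetrazol-5-yl it replaces, (tert-butyl)sulfamoyl has no ring and 2 hydrogen-bond acceptors instead of 5, at a nearly equal heavy-atom count of 8 against 9, but no measurement at hand assigns the step to any of these differences.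

The compounds shown leave open whether the higher number belongs to the sulfamoyl unit itself or to the tert-butyl on its nitrogen, a question that the unsubstituted sulfamoyl group or a methylsulfonyl group on the same aromatic carbon would address. They also leave open whether a tert-butyl amide or a carboxylic acid at this carbon would stay with compound 1 or fall with compound 4.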